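The source may hold more compounds than are shown below. What is called first, only, known or untested is meant among the compounds shown, and "the series" means these compounds.

Measured so far in an assay on isolated protein for binding affinity to Adrenergic receptor alpha-1 (Rattus norvegicus), read by radioligand binding; on this read-out higher numbers stand for weaker inhibition and lower numbers for stronger inhibition:
Compound 1, `O=C1C2CCCCN2C(=O)N1CN1CCN(c2ccccc2)CC1`, gives > 1000 nM, which is a limit of the assay rather than a number.
Compound 2, `O=C1C2CCCCN2C(=O)N1CN1CCN(c2cccc(Cl)c2)CC1`, gives 135 nM.
Compound 3, `O=C1C2CCCCN2C(=O)N1CCN1CCN(c2ccccc2)CC1`, gives > 1000 nM, again a limit of the assay and not a number.

The change from compound 1 to compound 2 is chloro in place of hydrogen on an aromatic carbon. It gave an at least 7.4-fold lower number from compound 1 to compound 2 (0.86 log units; beyond the scatter). Compound 3 shares that core type, but the difference between its core and the core of compound 1 is not broken down here.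

Compound 4, `O=C1C2CCCCN2C(=O)N1CCN1CCN(c2cccc(Cl)c2)CC1`, is not yet measured. It differs from compound 3 by chloro in place of hydrogen on an aromatic carbon, the same change as before. A step of about the same size is expected, an at least 3.3-fold lower number from compound 3 to compound 4 (0.52 log units; beyond the scatter), resting on an at least 7.4-fold lower number from compound 1 to compound 2 (0.86 log units; beyond the scatter). For compound 4 the expected value in this assay is therefore 300 nM, between 80 nM and 1500 nM.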

Compound 4, inhibition constant: 375 nM
Estimate against measurement, compound 4: 1.3-fold (0.10 log units) below; low and high end bracket the measured number.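

In this assay, chloro in place of hydrogen on the aromatic ring gives an at least 2.6-fold lower number from compound 3 to compound 4 (0.42 log units; beyond the scatter), so the change points the same way on both cores shown. Whether it carries over with the same size stays unsettled: the same change on two cores in this assay, an at least 7.4-fold lower number (0.86 log units; beyond the scatter) from compound 1 to compound 2 and an at least 2.6-fold lower number (0.42 log units; beyond the scatter) from compound 3 to compound 4; the limit leaves it open whether they differ. Compound 1 and compound 3 each stand at a limit of the assay, so both steps are minimum sizes and not true ones: the limit of > 1000 nM in this assay, at which 2 of the 4 values shown sit.

The compounds shown leave open whether a fluoro or a methoxy group in place of the chloro would also lower the number. They also leave open whether the step would survive on a core with a longer chain joining the two parts of the molecule.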